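The source may report more compounds than this note shows. Statements on the series, on what has been measured and on what is new or still open speak of the compounds shown alone.

Compound 2 `CCCCn1c(Cc2cc(OC)c(OC)c(OC)c2)nc2c(N)nc(F)nc21` gives the highest of the two numbers in a functional assay on MCF7 cells (Homo sapiens) for antiproliferative activity (a higher number here means a weaker inhibitor, a lower number a stronger inhibitor), with 24000 nM. Its nearest neighbour, compound 1 `C#CCCCn1c(Cc2cc(OC)c(OC)c(OC)c2)nc2c(N)nc(F)nc21`, gives 11000 nM in this assay; the step of a 2.2-fold higher number from compound 1 to compound 2 (0.34 log units; beyond the scatter) is the only measured one on this chain. Within the data shown here, compound 3 `COCCn1c(Cc2cc(OC)c(OC)c(OC)c2)nc2c(N)nc(F)nc21` differs from compound 2 by methoxy in place of ethyl on a saturated chain carbon, two bonds along the chain from an aromatic nitrogen, a change with no direct precedent; the measured step on the chain gives only a rough scale. A small shift in this assay, of uncertain direction, is therefore expected. Compound 3 is estimated at 20000 nM (range 7000 nM to 60000 nM), an expected step of a 1.2-fold lower number from compound 2 to compound 3 (0.08 log units; within the scatter).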

Compound 3, half-maximal inhibitory concentration: 64600 nM
The estimate for compound 3 lay 3.2-fold (0.51 log units) below the measured number; the measured number lies above the stated range.
By their numbers in this assay, from the lowest: compound 1; then compound 2; then compound 3.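

In this assay, methoxy in place of ethyl gives a 2.7-fold higher number from compound 2 to compound 3 (0.43 log units; beyond the scatter), so this chain position does not accept the swap without change, and the direction is towards a weaker inhibitor. Methoxy in place of propargyl gives a 5.9-fold higher number from compound 1 to compound 3 (0.77 log units; beyond the scatter), the widest step in this small set, with the methoxy compound 3 the weakest of the three. Nothing measured here accounts for these steps.

On these data alone, whether an amine or a hydroxyl at this position behaves like methoxy remains open. So does whether a longer chain carrying the ether oxygen recovers the number of compound 1.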